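A Methoxy Group Added to a Compound Without a Number

A few compounds are considered here, and "the series" means these few. Any claim that something is new, unique, unknown or untested is made for them only; others in the source may bear on it.

The compounds were tested in an assay on isolated protein for inhibition of vascular endothelial growth factor receptor 1 (Homo sapiens), read by ELISA, with a stated time of 20 min, tested at 1 uM; on this read-out higher numbers stand for more inhibition at the one concentration tested (going by the name of the read-out) and lower numbers for less inhibition. Compound 1 `COc1cc2ncnc(Nc3ccc(B(O)O)cc3)c2cc1OC` gives 49% in this assay. Compound 2 `OB(O)c1ccc2ncnc(Nc3ccc(F)c(Cl)c3)c2c1` is recorded in this assay as "not active" (no number reported), with no number attached, and compound 3 `COc1cc2ncnc(Nc3cccc(C#N)c3)c2cc1OC` is likewise recorded as "not active" (no number reported). Compound 2 therefore stands as one of two entries without a single number, while compound 1 alone carries a numerical result. Compound 4 `COc1cc2ncnc(Nc3ccc(F)c(Cl)c3)c2cc1B(O)O` differs from compound 2 by methoxy in place of hydrogen on an aromatic carbon. No change of one group has been measured in this assay, so the size of the step from compound 2 to compound 4 cannot be read from the data; a small rise, or none beyond the scatter, is expected. Compound 4 is estimated at 20%, within a range from 0% to 50%.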

Compound 4, a percentage reported as inhibition, at one concentration (the size of the read-out at that concentration, not a potency): "not active" (no number reported)
For compound 4 the study gives words and no number, and the estimate cannot be compared.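

In this assay compound 2 and compound 4 both carry words and no number, so no step can be read between them. The compounds shown leave open what the methoxy changes in this inhibition. No evidence given here bears on this result.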